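Replacing an ethyl tail with a methylpiperazine ring

The source may report more compounds than this note shows. Statements on the series, on what has been measured and on what is new or still open speak of the compounds shown alone.

Of the compounds shown here, two of the same core have been tested so far. Compound 1 `CCC/C=C/C(=O)Nc1cc2c(N3CCc4ccccc43)ncnc2cc1OC` gives 2920 nM in a functional assay on A549 cells (Homo sapiens) for antiproliferative activity, read by MTT assay, with a stated time of 72 h; a lower number here means a stronger inhibitor, a higher number a weaker inhibitor. Compound 2 `CCC/C=C/C(=O)Nc1cc2c(N3CCCc4ccccc43)ncnc2cc1OC` gives 1800 nM in this assay, which is the lowest of the two numbers, though the step of a 1.6-fold lower number from compound 1 to compound 2 (0.21 log units; within the scatter) keeps the pair inside the usual scatter of such a measurement. Compound 3 `COc1cc2ncnc(N3CCCc4ccccc43)c2cc1NC(=O)/C=C/CN1CCN(C)CC1` has not been measured yet. It differs from compound 2 in one place: 4-methylpiperazin-1-yl in place of ethyl on a saturated chain carbon bound to a double-bonded chain carbon. Among the measured compounds shown here, the only measured step, from compound 1 to compound 2, concerns the ring attached to the core and not the chain, so nothing observed bears directly on this new change. For the measured compounds named here, with no precedent, the expected step of a 1.5-fold lower number from compound 2 to compound 3 (0.18 log units; within the scatter) from compound 2 to compound 3 is given a wide margin rather than a firm direction. Compound 3 is therefore estimated at 1200 nM in this assay, with a plausible span from 300 nM to 5000 nM.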

Compound 3, half-maximal inhibitory concentration: 7830 nM
Compound 3: the middle estimate sits 6.5-fold (0.81 log units) below what was measured; measured number above the stated range.
By their numbers in this assay, from the lowest: compounds 2 and 1 (each within the scatter of the next); then compound 3.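

In this assay, putting 4-methylpiperazin-1-yl in place of ethyl on a saturated chain carbon bound to a double-bonded chain carbon gives a 4.4-fold higher number from compound 2 to compound 3 (0.64 log units; beyond the scatter). This is the first single change shown here to move the number beyond the scatter, so the end of the chain is a place where the structure matters to this antiproliferative read-out, and here the ring-bearing group comes out as the weaker choice, though the size of the step is modest. Nothing available explains the step, and no measurement bears on its cause.

This one change brings in a larger group, a ring and two nitrogen atoms together, so the compounds shown cannot tell which of these goes with the higher number. From the compounds shown here alone, a simple dimethylamino group, a morpholine ring or a longer plain carbon chain at the same place would be needed to pull these apart, and whether the step holds with the 2,3-dihydro-1H-indol-1-yl group of compound 1 also stays open.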